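Fluoro for chloro in a writhing-test series

This account rests on a few compounds, and the source may have more. Where it says the series, first, only, none or still open, it means among the compounds named here.

Measured compounds:
compound 1, `COc1ccc(Cc2n[nH]c(=S)n2N)cc1`: 30.2%
compound 2, `COc1ccc(Cc2nnc3n2N=C(c2ccc(Cl)cc2)CS3)cc1`: 33%

Both were run in a functional assay on the whole organism (strain BALB/c) with Mus musculus as the target, in the writhing test, with a stated time of 1 h, at a dose of 100 mg/kg by the oral route; on this read-out lower numbers stand for a weaker effect and higher numbers for a stronger effect at the one dose given. In this assay compound 1 gives 30.2%, and compound 2 gives 33%. On the numbers shown compound 2 stands at the top of the two, but its nearest neighbour is compound 1 and the gap between them is within the scatter, so the two read as equal and nothing separates them. Among the compounds with values here, no pair of measured compounds differs in one place only, so no single-change step can be read from what has been measured.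

The next compound, compound 3, `COc1ccc(Cc2nnc3n2N=C(c2ccc(F)cc2)CS3)cc1`, follows from compound 2 by one change:

fluoro in place of chloro on an aromatic carbon

Within the data shown here, with no measured step to lean on, the change from compound 2 to compound 3 is expected to give a number 2 percentage points lower from compound 2 to compound 3 (within the scatter), a step that does not reach beyond the scatter in either direction. Compound 3 is therefore estimated at 31% in this assay, with the range set from 18% to 45%.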

Compound 3, a percentage reported as inhibition, in the whole organism at one dose (the size of the read-out at that dose, not a potency): 26.3%
Beside the measured number, compound 3's estimate is 4.7 percentage points above it, within the range that was stated.
By their numbers in this assay, from the lowest: compounds 3, 1 and 2 (each within the scatter of the next).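

In this assay, within the data shown here, the change from 4-chlorophenyl to 4-fluorophenyl gives a number 6.7 percentage points lower from compound 2 to compound 3 (within the scatter) and is the first single-change step, since the earlier pair differed in more than one place. At this position, on an aromatic carbon para to a large group, one halogen can therefore stand in for the other with no difference that can be told from the scatter, and compound 2 and compound 3 read as equal at the one dose given. No measured evidence in hand explains this step or bears on it.

The compounds shown leave open whether any group at this position moves the read-out beyond the scatter, as only chloro and fluoro appear there, so a bromo, an amine or a carboxylic acid in that place would test how far the tolerance seen here extends. Going by these compounds, a single dose also gives the size of the effect and not a potency, so a real difference between chloro and fluoro that is small or shows only at other doses remains open.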